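A few compounds are considered here, and "the series" means these few. Any claim that something is new, unique, unknown or untested is made for them only; others in the source may bear on it.

Measured in an ADME assay on L929 cells (Mus musculus) for cytotoxicity, with a stated time of 72 h; a lower number here means a stronger inhibitor, a higher number a weaker inhibitor:

- Compound 1 `CCOC(=O)COc1ccc2c(c1)B(O)OC2`: > 10 ug/mL
- Compound 2 `COC(=O)COc1ccc2c(c1)B(O)OC2`: > 10 ug/mL
- Compound 3 `CCOC(=O)C(C)Oc1ccc2c(c1)B(O)OC2`: > 10 ug/mL

Each of these entries is a limit of the assay, not a number. Compound 3 therefore has no exact position, and its > 10 ug/mL is only a limit. Among the compounds with values here, the whole series so far comes down to the limit of > 10 ug/mL in this assay, at which 3 of the 3 values shown sit.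

Compound 4 `CCOC(=O)C(CC)Oc1ccc2c(c1)B(O)OC2` extends the methyl on the chain of compound 3 to an ethyl: methyl in place of hydrogen on a saturated chain carbon, two bonds along the chain from a carbonyl carbon and an oxygen on an aromatic ring.

Two measured changes bear on this one. The closer is a step that the two limits leave unreadable from compound 1 to compound 3, where a methyl was added to the same chain. The other is a step that the two limits leave unreadable from compound 1 to compound 2, where a methyl was removed. Neither has a readable size, yet compound 1, compound 2 and compound 3 all remain at the limit in this assay. No step in either direction beyond the usual scatter is therefore expected, and the expected result is a step that the limit leaves unreadable from compound 3 to compound 4. Most likely the assay will again report only a limit. For compound 4 the estimated value is 15 ug/mL, with an expected range of 8 ug/mL to 50 ug/mL.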

Compound 4, half-maximal inhibitory concentration: > 10 ug/mL
Compound 4: a limit, no number (the forecaster's own chance of this, stated with the estimate: 85%); the middle value does not contradict the limit.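

In this assay compound 4 gives > 10 ug/mL, again a limit and not a number, so its steps from compound 1 and compound 3 cannot be read: the limit of > 10 ug/mL in this assay, at which 4 of the 4 values shown sit. The compounds shown leave open whether any of these chain changes alters the true values behind that limit.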